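Enlarging the Sulfonyl Substituent of Compound 3

A few compounds are considered here, and "the series" means these few. Any claim that something is new, unique, unknown or untested is made for them only; others in the source may bear on it.

Compound 1 `CCN1CCN(S(=O)(=O)CCCN2CCC(CNC(=O)c3cccc4c3OCCO4)CC2)CC1`: 0.0501 nM
Compound 2 `O=C(NCC1CCN(CCCS(=O)(=O)N2CCN(Cc3cccnc3)CC2)CC1)c1cccc2c1OCCO2`: 0.159 nM
Compound 3 `CS(=O)(=O)N1CCN(S(=O)(=O)CCCN2CCC(CNC(=O)c3cccc4c3OCCO4)CC2)CC1`: 0.316 nM

In an assay on isolated protein for inhibition of 5-hydroxytryptamine receptor 4 (Homo sapiens) (a higher number here means a weaker inhibitor, a lower number a stronger inhibitor), compound 3 stands at the high end of the three numbers: the step of a 6.3-fold higher number from compound 1 to compound 3 (0.80 log units; beyond the scatter) lies beyond the scatter, whereas a 2.0-fold higher number from compound 2 to compound 3 (0.30 log units; within the scatter) does not. Compound 4 `O=C(NCC1CCN(CCCS(=O)(=O)N2CCN(S(=O)(=O)c3ccc(F)cc3)CC2)CC1)c1cccc2c1OCCO2` differs from compound 3 in one place: 4-fluorophenyl in place of methyl on a sulfonyl sulfur. Among the compounds with values here, no measured step alters the sulfonyl sulfur itself. The nearest comparison is compound 2, where a (pyridin-3-yl)methyl group on the ring nitrogen gives 0.159 nM, close to compound 3 a 2.0-fold higher number from compound 2 to compound 3 (0.30 log units; within the scatter). A larger group at this end of the molecule therefore appears tolerated, and no step beyond the scatter is expected in this assay. Compound 4 is expected to give about 0.3 nM, between 0.1 nM and 1 nM. This estimate corresponds to a 1.1-fold lower number from compound 3 to compound 4 (0.02 log units; within the scatter).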

Compound 4, inhibition constant: 0.0316 nM
Beside the measured number, compound 4's estimate is 9.5-fold (0.98 log units) above it, outside the stated range (below it).
By their numbers in this assay, from the lowest: compounds 4 and 1 (each within the scatter of the next); then compounds 2 and 3 (each within the scatter of the next).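

In this assay, within the data shown here, the sulfonyl sulfur proves responsive, which no earlier step could show: placing 4-fluorophenyl there in place of methyl gives a clear shift toward stronger inhibition (a 10-fold lower number from compound 3 to compound 4 (1.00 log units; beyond the scatter)). The (4-fluorophenyl)sulfonyl group also outdoes the (pyridin-3-yl)methyl group on the ring nitrogen (a 5.0-fold lower number from compound 2 to compound 4 (0.70 log units; beyond the scatter)), whereas its step from the ethyl group stays within the scatter (a 1.6-fold lower number from compound 1 to compound 4 (0.20 log units; within the scatter)). No evidence at hand bears on this result. Still open, from the compounds shown here alone, is whether the fluorine matters or the aromatic ring alone suffices; phenyl or 4-methoxyphenyl on the same sulfur would separate the two.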